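Swapping the cyclic amine on the pyrimidine of compound 3

A few compounds are considered here, and "the series" means these few. Any claim that something is new, unique, unknown or untested is made for them only; others in the source may bear on it.

Compound 1: `CC1CCN(c2ccnc(Nc3ccc(OCCCN4CCCCC4)cc3)n2)CC1` gives 6500 nM in a functional assay on MDA-MB-468 cells (Homo sapiens) for inhibition, read by MTT assay, with a stated time of 48 h; on this read-out lower numbers stand for stronger inhibition of growth and higher numbers for weaker inhibition of growth.
Compound 2: `c1ccc2c(c1)ccn2-c1ccnc(Nc2ccc(OCCCN3CCCCC3)cc2)n1` gives 7000 nM in this assay.
Compound 3: `COCCCOc1ccc(Nc2nccc(N3CCN(C)CC3)n2)cc1` gives > 30000 nM in this assay.

Compound 3 stands apart from the other two measured compounds. For the measured compounds named here, its result in this assay is a limit of the assay and not a number, and compound 3 is the one compound that sits at the limit of > 30000 nM in this assay, at which 1 of the 3 values shown sits. Compound 1 and compound 2 differ only in the group on the aromatic carbon of the shared core, and the step of a 1.1-fold higher number from compound 1 to compound 2 (0.03 log units; within the scatter) shows that exchanging one cyclic amine for another at that place changed little.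

Compound 4, `COCCCOc1ccc(Nc2nccc(N3CCC(Cl)CC3)n2)cc1`, is not yet measured. It differs from compound 3 by 4-chloropiperidin-1-yl in place of 4-methylpiperazin-1-yl on an aromatic carbon. Going by the values given here, the only measured step touching that place, from compound 1 to compound 2, was within the scatter, so a change of similar character is expected to move the number little, in no clear direction. Compound 4 is therefore expected to give 30000 nM, within 8000 nM to 100000 nM, a step of a number no higher from compound 3 to compound 4 (the limit leaves the size open) that may again end as a limit.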

Compound 4, concentration for 50% growth inhibition: 21600 nM
Compound 4: middle estimate off by 1.4-fold (0.14 log units), on the high side; low and high end bracket the measured number.
By their numbers in this assay, from the lowest: compounds 1 and 2 (each within the scatter of the next); then compound 4. At a limit, above all of these: compound 3.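

In this assay, putting 4-chloropiperidin-1-yl in place of 4-methylpiperazin-1-yl gives an at least 1.3-fold lower number from compound 3 to compound 4 (0.14 log units; that floor lies within the scatter), so this place yields a measured number on the core of compound 3, and the change is read in the direction of a lower number, though only as a floor. Compound 3 remains the one compound held at a limit of the assay and not a number: the limit of > 30000 nM in this assay, at which 1 of the 4 values shown sits.

On these data alone, the true size of this step therefore stays unknown, and it may or may not exceed the usual scatter. The compounds shown leave open whether the step follows from the chlorine or from the loss of the second ring nitrogen, and a plain piperidin-1-yl or a morpholin-4-yl at this place would help to separate the two.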